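The source may report more compounds than this note shows. Statements on the series, on what has been measured and on what is new or still open speak of the compounds shown alone.

The measured compounds and their numbers:

Compound 1 `Cc1occc1-c1nnc2sc(-c3ccnc4ccccc34)nn12`: 12.5%
Compound 2 `COc1ccc(Cl)c(-c2nnc3n2NC(c2ccco2)S3)c1`: 13.9%
Compound 3 `Cc1occc1-c1nnc2n1NC(c1ccc[nH]1)S2`: 13.7%

All three were tested in a functional assay on the whole organism (strain Wistar Albino) for inhibition, with Rattus norvegicus as the target, read by paw edema, with a stated time of 1 h, at a dose of 20 mg/kg; a higher number here means more inhibition at the dose given (going by the name of the read-out), a lower number less inhibition. Compound 1 gives 12.5%, compound 2 gives 13.9% and compound 3 gives 13.7% in this assay. Compound 2 carries the highest of the three numbers, yet its gap to compound 3 and its gap to compound 1 both lie within the usual scatter of such measurements, so the three compounds cannot be told apart on these numbers alone; none of them reduces the paw swelling to a large degree at the dose used.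

Compound 4 `COc1ccc(Cl)c(-c2nnc3n2NC(c2cccn2C)S3)c1` has not yet been tested. It differs from compound 2 in one place: 1-methyl-1H-pyrrol-2-yl in place of furan-2-yl on a saturated ring carbon. The methyl-bearing nitrogen ring takes the place of the oxygen ring, while the rest of compound 2 is kept. Going by the values given here, no measured pair in this set shows what such an exchange does to the read-out, so there is no step to lean on. With all three measured numbers sitting close together, compound 4 is expected to land in the same region, and the step of a number 0.1 percentage points higher from compound 2 to compound 4 (within the scatter) is expected to stay within the scatter, in no firm direction. Compound 4 is therefore estimated at 14%, with a range from 5% to 25%.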

Compound 4, a percentage reported as inhibition, in the whole organism at one dose (the size of the read-out at that dose, not a potency): 14.1%
The estimate for compound 4 lay 0.1 percentage points below the measured number, and the stated range covers the measured number.
By their numbers in this assay, from the lowest: compounds 1, 3, 2 and 4 (each within the scatter of the next).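

In this assay, going by these compounds alone, placing 1-methyl-1H-pyrrol-2-yl where furan-2-yl stood on the saturated ring carbon gives a number 0.2 percentage points higher from compound 2 to compound 4 (within the scatter) and provides the first direct comparison at this position. The earlier compounds shown here could not show this, since none of them differ in one place only. Here, a five-membered aromatic ring with an oxygen and one with a methyl-bearing nitrogen cannot be told apart by reduced paw swelling at this single dose and time, and no other data explain that outcome.

The compounds shown leave open whether this position would separate from the scatter with a different kind of group, such as a phenyl ring, a simple methyl group or a chain ending in an amine. They also leave open what the methyl on the ring nitrogen contributes, which would need a plain 1H-pyrrol-2-yl or an ethyl in its place on the same core as compound 4.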